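This account rests on a few compounds, and the source may have more. Where it says the series, first, only, none or still open, it means among the compounds named here.

In a functional assay on liver (Sus scrofa) for inhibition of squalene monooxygenase (Homo sapiens), using microsomes (a higher number here means a weaker inhibitor, a lower number a stronger inhibitor), compound 2 `CCN(C/C=C/C#CC(C)(C)C)Cc1cccc(OC[Si](C)(C)c2ccc(C(N)=O)cc2)c1` gives 5000 nM, the higher of the two numbers recorded, and so the weaker inhibitor of the pair. Its only companion, compound 1 `CCN(CC#CC#CC(C)(C)OC)Cc1cccc(OC[Si](C)(C)c2ccccc2C)c1`, gives 70 nM in this assay, a gap well beyond the scatter; the two compounds differ both in the chain on the nitrogen and in the ring on silicon, so no single change accounts for it. Compound 3 `CCN(C/C=C/C#CC(C)(C)C)Cc1cccc(OC[Si](C)(C)C2CCCCC2)c1` keeps the chain of compound 2 and alters only the ring on silicon: cyclohexyl in place of 4-carbamoylphenyl on a silicon. For the measured compounds named here, no measured pair isolates this change. Compound 1 gives 70 nM with a silicon ring lacking the carbamoyl, which hints at a lower number for compound 3, though compound 1 differs in its chain as well. The step from compound 2 to compound 3 is expected to be a 13-fold lower number from compound 2 to compound 3 (1.10 log units; beyond the scatter), beyond the scatter. For compound 3 the estimate in this assay is 400 nM, within a range from 100 nM to 2000 nM.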

Compound 3, half-maximal inhibitory concentration: 20000 nM
Compound 3: the middle estimate sits 50-fold (1.70 log units) below what was measured; the whole stated range lies below it.
By their numbers in this assay, from the lowest: compound 1; then compound 2; then compound 3.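

For the compounds shown here, replacing 4-carbamoylphenyl with cyclohexyl on a silicon gives a 4.0-fold higher number from compound 2 to compound 3 (0.60 log units; beyond the scatter) in this assay, so this is the first pair to show, with the chain held fixed, that the group at this place alters the number. Here, the carbamoylphenyl compound is the stronger inhibitor of the two, so losing the carbamoyl and the aromatic ring together does not bring a lower number. Nothing measured here gives a reason for this step.

This change alters the ring and removes the carbamoyl at once, so the pair cannot separate the two, and the compounds shown include no plain phenyl on the silicon that could do so. Going by these compounds, whether the step would hold with the chain of compound 1 also remains open.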